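Anilino to benzylamino on the shared core

A few compounds are considered here, and "the series" means these few. Any claim that something is new, unique, unknown or untested is made for them only; others in the source may bear on it.

Compound 3, `Cc1cc(=O)oc2cc(OCc3nc(N)nc(Nc4ccc(O)cc4)n3)ccc12`, was taken into an assay on COS-7 cells for agonist activity at Free fatty acid receptor 1 (Homo sapiens), read by scintillation counting and inositol phosphate accumulation, with a stated time of 90 min (a lower number here means that less compound is needed, a higher number that more compound is needed for the effect), but returned no single number there: its entry reads "not determined" (no result reported). The same holds for compound 2, `Cc1cc(=O)oc2cc(OCc3nc(N)nc(Nc4cccc(O)c4)n3)ccc12`, which also stands at "not determined" (no result reported) in this assay. Going by the values given here, the only compound of the set with a number is compound 1, `Cc1cc(=O)oc2cc(OCc3nc(N)nc(Nc4ccc(C5CC5)cc4)n3)ccc12`, which in this assay gives 700 nM. Compound 3 therefore has no measured position on the scale; it stands alongside one further entry without a number, and the series as a whole offers one reference point only.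

Compound 4, `Cc1cc(=O)oc2cc(OCc3nc(N)nc(NCc4ccc(F)cc4)n3)ccc12`, differs from compound 3 by 4-fluorobenzyl in place of 4-hydroxyphenyl on a nitrogen on an aromatic ring. The change removes the hydrogen-bond donor and the hydrogen-bond acceptor counted on the leaving group and inserts a further carbon between the ring nitrogen and the aromatic ring. Among the compounds with values here, no step between measured compounds is available for this pair, so the size of the change cannot be read from the series. The working expectation for compound 4 in this assay is a value somewhat weaker than that of compound 1, a step in the direction of more compound needed, though a result within the scatter of compound 1 cannot be ruled out. Compound 4 is estimated at 2000 nM, with a range from 500 nM to 8000 nM.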

Compound 4, half-maximal effective concentration: 7820 nM
Compound 4: the middle estimate sits 3.9-fold (0.59 log units) below what was measured; the range from low to high includes it.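

In this assay the group on this nitrogen now has one readable step: an 11-fold higher number from compound 1 to compound 4 (1.05 log units; beyond the scatter) with 4-fluorobenzyl in place of 4-cyclopropylphenyl, so the read-out is sensitive to what sits at this place on the shared core. Steps from compound 2 and compound 3 to compound 4 cannot be read, as neither has a number, and the change from 4-hydroxyphenyl to 4-fluorobenzyl therefore has no size. No measured evidence on the origin of the step is at hand.

The step from compound 1 to compound 4 carries two differences at once, the changed ring substituent and the further carbon on the nitrogen, and the compounds shown do not separate them; a 4-fluorophenyl or a 4-cyclopropylbenzyl group on the same nitrogen would do so. Also open, on these data alone, is how the read-out responds to a longer chain, such as 2-phenylethyl, between this nitrogen and the aromatic ring, or to a carboxylic acid on that ring.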